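Methyl in place of methoxy at the assay limit

This account rests on a few compounds, and the source may have more. Where it says the series, first, only, none or still open, it means among the compounds named here.

Compound 1 (`C/C(=C\CC/C(C)=C/CC[C@@H]1[C@@]2(C)CCC(=O)C(C)(C)[C@H]2CC[C@@]1(C)O)CC/C=C(\C)C(=O)OCc1cn(-c2cccc(C)c2)nn1`), compound 2 (`C/C(=C\CC/C(C)=C/CC[C@@H]1[C@@]2(C)CCC(=O)C(C)(C)[C@H]2CC[C@@]1(C)O)CC/C=C(\C)C(=O)OCc1cn(-c2cccc(Br)c2)nn1`) and compound 3 (`COc1ccc(-n2cc(COC(=O)/C(C)=C/CC/C(C)=C/CC/C(C)=C/CC[C@@H]3[C@@]4(C)CCC(=O)C(C)(C)[C@H]4CC[C@@]3(C)O)nn2)cc1`) share one core and differ in the group on an aromatic nitrogen. In an ADME assay on L132 cells (Homo sapiens) for cytotoxicity, read by MTT assay, with a stated time of 48 h (a lower number here means a stronger inhibitor, a higher number a weaker inhibitor), compound 1 gives > 150000 nM as a limit of the assay and not a number. In this assay compound 2 gives > 150000 nM as a limit too. Compound 3 gives > 150000 nM as a limit as well, so it has no number of its own to start from.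

Compound 4 (`C/C(=C\CC/C(C)=C/CC[C@@H]1[C@@]2(C)CCC(=O)C(C)(C)[C@H]2CC[C@@]1(C)O)CC/C=C(\C)C(=O)OCc1cn(-c2ccc(C)cc2)nn1`) follows from compound 3 with methyl in place of methoxy on an aromatic carbon, para to a large group (methyl in place of methoxy on an aromatic carbon). Within the data shown here, three measured steps bear on this change: a step that the two limits leave unreadable from compound 1 to compound 2 with bromo in place of methyl, a step that the two limits leave unreadable from compound 1 to compound 3 with 4-methoxyphenyl in place of 3-methylphenyl, and a step that the two limits leave unreadable from compound 2 to compound 3 with 4-methoxyphenyl in place of 3-bromophenyl. None of them offers a size, so no step beyond the scatter and no direction can be expected in this assay on their strength. Compound 1, compound 2 and compound 3 all stand at the limit of > 150000 nM in this assay, at which 3 of the 3 values shown sit, and compound 4 is therefore expected to be reported as a limit as well. The estimated step (a step that the limit leaves unreadable from compound 3 to compound 4) is expected to stay within the scatter. For compound 4 the estimated value is 200000 nM (expected range 100000 nM to 400000 nM).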

Compound 4, half-maximal inhibitory concentration: > 150000 nM
Compound 4 ended at the assay's limit; the forecaster's own chance of this, stated with the estimate: 90%; the middle value is on the limit's open side.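

In this assay compound 4 gives > 150000 nM, a limit of the assay and not a number. Among these compounds, no step from compound 1, compound 2 or compound 3 to compound 4 can be read, since all four compounds share one limit: the limit of > 150000 nM in this assay, at which 4 of the 4 values shown sit. The compounds shown leave open whether any group on the aromatic nitrogen would give a measurable value in this assay.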